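From 2,4-Difluorobenzyl to 4-Cyanobenzyl: What Comes Next?

The source may hold more compounds than are shown below. What is called first, only, known or untested is meant among the compounds shown, and "the series" means these compounds.

Little is known so far about this small set of compounds. In a toxicity assay on NIH3T3 cells (Mus musculus) for cytotoxicity, read by resazurin assay (a higher number here means that more compound is needed for the effect, a lower number that less compound is needed), compound 1 `COC(=O)c1ccc(NCc2cncn2Cc2ccccc2-c2ccccc2)cc1-c1ccccc1` has the entry "not determined" (no result reported), so it offers no number to work from. Compound 2 `COC(=O)c1ccc(NCc2cncn2Cc2ccc(F)cc2F)cc1-c1ccccc1` gives > 1000 nM, which is a limit of the assay and not a number. Compound 3 `COC(=O)c1ccc(NCc2cncn2Cc2ccc(C#N)cc2)cc1-c1ccccc1` keeps the shared core but carries 4-cyanophenyl in place of 2,4-difluorophenyl on a saturated chain carbon bound to an aromatic nitrogen. Among the compounds with values here, no measured pair of compounds shows what a swap like this does in this assay, so the expectation is a cautious one: no step beyond the usual scatter, and no particular direction. The estimated change is a step that the limit leaves unreadable from compound 2 to compound 3. For compound 3 the expected value is 2000 nM, with an estimated range from 600 nM to 10000 nM.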

Compound 3, half-maximal effective concentration: > 10000 nM
Compound 3: only a limit was reported (the forecaster's own chance of this, stated with the estimate: 70%); middle value at least 5.0-fold (0.69 log units) away from the limit.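

Within the data shown here, compound 2 and compound 3 each give only a limit in this assay, so no step between them can be read. The compounds shown leave open whether 4-cyanobenzyl in place of 2,4-difluorobenzyl changes the amount of compound needed for the effect at all.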